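A few compounds are considered here, and "the series" means these few. Any claim that something is new, unique, unknown or untested is made for them only; others in the source may bear on it.

Compound 1, `COc1ccc(F)cc1NC(=O)CN1CCN(S(=O)(=O)N2CCC(C)CC2)CC1` — in an assay on HEK293 cells for inhibition of potassium channel subfamily T member 1 (Homo sapiens), read by thallium flux (a higher number here means a weaker inhibitor, a lower number a stronger inhibitor), compound 1 gives 4900 nM.
Compound 2, `CC1CCN(S(=O)(=O)N2CCN(CC(=O)Nc3cc(Cl)ccc3OC(C)C)CC2)CC1` — in this assay compound 2 gives 5100 nM.
Compound 3, `COc1ccc(Cl)cc1NC(=O)CN1CCN(S(=O)(=O)N2CCC(C)CC2)C[C@H]1C` — in this assay compound 3 gives 2400 nM.

Among these three numbers, compound 2 holds the highest value in this assay. The gap to compound 1 is within the usual scatter of repeated measurements, so the two compounds cannot be told apart on these data. Compound 3 sits furthest away, with a number low enough to lie beyond the scatter, and its structure differs from compound 2 in more than one place, so no single change can be credited for that gap.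

Compound 4, `CCOc1ccc(Cl)cc1NC(=O)CN1CCN(S(=O)(=O)N2CCC(C)CC2)CC1`, has not yet been measured in this assay. It differs from compound 2 in one place: hydrogen in place of methyl on a saturated chain carbon bound to an oxygen on an aromatic ring and a saturated chain carbon. Among the compounds with values here, no step between two measured compounds isolates this change, so there is no measured precedent to lean on. With so small a change, and with the closest analogues spread over a narrow range, the expected step from compound 2 to compound 4 is a 1.2-fold lower number from compound 2 to compound 4 (0.08 log units; within the scatter), which is small and not clearly beyond the scatter. The estimated value for compound 4 in this assay is 4200 nM, with a likely range from 2000 nM to 9000 nM.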

Compound 4, half-maximal inhibitory concentration: 7100 nM
For compound 4 the middle estimate is 1.7-fold (0.23 log units) below the measured one; low and high end bracket the measured number.
By their numbers in this assay, from the lowest: compound 3; then compounds 1, 2 and 4 (each within the scatter of the next).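

In this assay, shortening isopropoxy to ethoxy gives a 1.4-fold higher number from compound 2 to compound 4 (0.14 log units; within the scatter), a step within the scatter, so on these data the two groups on this oxygen cannot be told apart. Within the data shown here, this is the first measured step at this position, and it shows that removing one methyl from the isopropyl chain produces no difference that can be resolved in this assay. The wider replacement of 5-fluoro-2-methoxyphenyl by 5-chloro-2-ethoxyphenyl on the amide-type nitrogen gives a 1.4-fold higher number from compound 1 to compound 4 (0.16 log units; within the scatter), also within the scatter, so this change cannot be separated from repeat-to-repeat variation either, and no measurement offered here bears on what lies behind these small steps.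

What the compounds shown leave open is whether this position stays equally flat with a group of another kind, such as a longer butoxy chain, a free hydroxyl or an amine in place of the isopropoxy or ethoxy group. They also leave open whether any change at this position could reach beyond the scatter in either direction.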